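Removing an allyl group from a pyridyl ketone series

This account rests on a few compounds, and the source may have more. Where it says the series, first, only, none or still open, it means among the compounds named here.

Of the compounds shown here, three have been tested in a functional assay on HeLa cells (Homo sapiens) for cytotoxicity, read by sulforhodamine B assay, with a stated time of 48 h; a lower number here means a stronger inhibitor, a higher number a weaker inhibitor. Compound 1, `C=CCOc1c(Cl)cccc1C(=O)c1cccnc1`, gives 100000 nM. Compound 2, `O=C(c1cccnc1)c1cccc(Cl)c1O`, gives 21000 nM. The two differ by a single change, (hydrogen in place of allyl on an oxygen on an aromatic ring), and this change made a step of a 4.8-fold lower number from compound 1 to compound 2 (0.68 log units; beyond the scatter). Compound 3, `C=CCOc1ccc(C)cc1C(=O)c1cccnc1`, gives 94000 nM in this assay; how its core differs from that of compound 1 is not broken down here. Compound 4, `Cc1ccc(O)c(C(=O)c2cccnc2)c1`, has not yet been measured. It differs from compound 3 by hydrogen in place of allyl on an oxygen on an aromatic ring, the same change that was made from compound 1 to compound 2, at the same kind of place, an oxygen on an aromatic ring flanked by aromatic carbon. Only this one earlier example of the change exists among these compounds, and compound 3 carries a different core than compound 1, so the expected step is uncertain. Still, the step is expected to be of similar size, about a 4.3-fold lower number from compound 3 to compound 4 (0.63 log units; beyond the scatter), resting on the step from compound 1 to compound 2 in this assay. Compound 4 is therefore estimated to give around 22000 nM, likely between 8000 nM and 70000 nM.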

Compound 4, half-maximal inhibitory concentration: 26000 nM
Compound 4: the middle estimate sits 1.2-fold (0.07 log units) below what was measured, within the range that was stated.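

Replacing allyl with hydrogen on the oxygen again gives a lower number in this assay, with a 3.6-fold lower number from compound 3 to compound 4 (0.56 log units; beyond the scatter). Set beside the earlier example, the two steps agree: the same change on two cores in this assay, a 4.8-fold lower number (0.68 log units; beyond the scatter) from compound 1 to compound 2 and a 3.6-fold lower number (0.56 log units; beyond the scatter) from compound 3 to compound 4, 1.3-fold (0.12 log units) apart, within the scatter of two such steps. Going by these compounds alone, the change therefore carries over from the core of compound 1 to the core of compound 3 at much the same size, but this rests on only two pairs in a single assay, and it shows neither why the number falls nor that the same step would appear on any other core.

The compounds shown carry only allyl or hydrogen on this oxygen, so it remains open whether a methyl, a longer chain or a group bearing a carboxylic acid there would give a number closer to that of the allyl compounds or the hydroxy compounds. Also open, as far as these compounds go, is how the number would respond to an amine in place of the chlorine of compound 2 or the methyl of compound 4.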